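The compounds below may be only part of what the source reports. "The series", "measured", "known", "first", "only" and "open" are said of these compounds alone.

Measured compounds in a functional assay on CHO cells for agonist activity at Free fatty acid receptor 1 (Homo sapiens), read by FLIPR and calcium flux; on this read-out higher numbers stand for an effect only at larger amounts of compound and lower numbers for an effect already at smaller amounts:
- compound 1 `Cc1cccc(C)c1-c1cccc(COc2ccc(S(=O)(=O)CC(=O)O)cc2)c1`: 66.1 nM
- compound 2 `COc1cc(C)c(-c2cccc(COc3ccc(S(=O)(=O)CC(=O)O)cc3)c2)c(C)c1`: 57.5 nM
- compound 3 `COc1cc(C)c(-c2cccc(COc3ccc4c(c3)C(=O)CC4CC(=O)O)c2)c(C)c1`: 234 nM

Compound 2 carries the lowest number of the three, though the step of a 1.1-fold lower number from compound 1 to compound 2 (0.06 log units; within the scatter) is within the scatter, so compound 1 and compound 2 are not distinguished. Compound 3 sits furthest away, with a clearly higher number on its different core.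

Compound 4 `CCOc1cc(C)c(-c2cccc(COc3ccc(S(=O)(=O)CC(=O)O)cc3)c2)c(C)c1` differs from compound 2 by methyl in place of hydrogen on a saturated chain carbon bound to an oxygen on an aromatic ring. Among the compounds with values here, the only measured step bearing on this position is a 1.1-fold lower number from compound 1 to compound 2 (0.06 log units; within the scatter), where introducing the methoxy itself moved the number by an amount within the scatter. Nothing in the series speaks for a change beyond the scatter from extending methoxy to ethoxy.

For compound 4 in this assay the expected step is a 1.0-fold lower number from compound 2 to compound 4 (0.02 log units; within the scatter), essentially none. Compound 4 is therefore estimated at 55 nM, with a range of 25 nM to 120 nM.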

Compound 4, half-maximal effective concentration: 63.1 nM
The estimate for compound 4 lay 1.1-fold (0.06 log units) below the measured number, and the stated range covers the measured number.
By their numbers in this assay, from the lowest: compounds 2, 4 and 1 (each within the scatter of the next); then compound 3.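

In this assay the extension of methoxy to ethoxy gives a 1.1-fold higher number from compound 2 to compound 4 (0.04 log units; within the scatter) and so does not distinguish compound 2 from compound 4. Set against hydrogen, ethoxy gives a 1.0-fold lower number from compound 1 to compound 4 (0.02 log units; within the scatter) and so, like methoxy, does not separate from hydrogen at this position. Nothing at hand offers a reason for these readings.

Open, from the compounds shown here alone, is whether a longer chain, or an amine on the chain, would give a step beyond the scatter. Also open, going by these compounds, is whether ethoxy reads the same on the core of compound 3.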